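This account rests on a few compounds, and the source may have more. Where it says the series, first, only, none or still open, it means among the compounds named here.

Compound 1 `O=[N+]([O-])c1ccc(N/C(=N\O)c2ccccc2F)c2nonc12` gives 63 nM in an assay on isolated protein for inhibition of Indoleamine 2,3-dioxygenase 1 (Homo sapiens), read by spectrophotometry, with a stated time of 1 h; on this read-out higher numbers stand for weaker inhibition and lower numbers for stronger inhibition
Compound 2 `O=[N+]([O-])c1ccc(N/C(=N\O)c2ccccc2Br)c2nonc12` gives 80 nM in this assay
Compound 3 `Cc1cccc(/C(=N/O)Nc2ccc([N+](=O)[O-])c3nonc23)c1` gives 163 nM in this assay

Compound 3 shows the highest number of the three. The step is a 2.6-fold higher number from compound 1 to compound 3 (0.41 log units; beyond the scatter) and a 2.0-fold higher number from compound 2 to compound 3 (0.31 log units; beyond the scatter), both beyond the scatter, so compound 3 is the weakest of the measured set in this assay.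

Compound 4 `O=[N+]([O-])c1ccc(N/C(=N\O)c2cccc(F)c2)c2nonc12` keeps the core of compound 3 and differs only in the change (fluoro in place of methyl on an aromatic carbon), the same difference read one bond further out being 3-methylphenyl to 3-fluorophenyl. For the measured compounds named here, no measured step swaps methyl for fluoro at this place. Going by the values given here, the one step that exchanges halogens on an aromatic carbon, a 1.3-fold higher number from compound 1 to compound 2 (0.10 log units; within the scatter), lies within the scatter, and the steps into compound 3 concern the ring pattern rather than the group itself. A step beyond the scatter in either direction in this assay is therefore not expected for compound 4, though a small move toward compounds 1 and 2 cannot be excluded.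

Compound 4 is estimated at 130 nM, in the range 55 nM to 320 nM, which means an expected step of a 1.3-fold lower number from compound 3 to compound 4 (0.10 log units; within the scatter).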

Compound 4, half-maximal inhibitory concentration: 75 nM
The estimate for compound 4 lay 1.7-fold (0.24 log units) above the measured number; the measured number falls inside the stated range.
By their numbers in this assay, from the lowest: compounds 1, 4 and 2 (each within the scatter of the next); then compound 3.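

For the compounds shown here, on this aromatic carbon, fluoro in place of methyl gives a 2.2-fold lower number from compound 3 to compound 4 (0.34 log units; beyond the scatter) in this assay, the first direct reading of this exchange, and the step lies beyond the scatter. With 3-fluorophenyl in place of 2-fluorophenyl, the result is a 1.2-fold higher number from compound 1 to compound 4 (0.08 log units; within the scatter) and lies within the scatter, as does a 1.1-fold lower number from compound 2 to compound 4 (0.03 log units; within the scatter) for 3-fluorophenyl in place of 2-bromophenyl, so among these compounds the higher number of compound 3 goes with its methyl and not with substitution at this place as such. Nothing available here explains these steps.

The compounds shown leave open how methoxy, an amine or a carboxylic acid on this carbon would compare with fluoro and methyl. They also leave open whether 2-methylphenyl would stay with compound 3 or join the halogen-bearing compounds.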